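Methyl for chloro on the shared core of compound 2

The compounds below may be only part of what the source reports. "The series", "measured", "known", "first", "only" and "open" are said of these compounds alone.

Measured compounds:
compound 1, `Clc1cccc2c(Cc3cc4ccccc4[nH]3)c[nH]c12`, 2800 nM
compound 2, `Clc1ccc2[nH]cc(Cc3cc4ccccc4[nH]3)c2c1`, 10000 nM

In an assay on HepG2 cells for inhibition of Proprotein convertase subtilisin/kexin type 9 (Homo sapiens), read by AlphaLISA, with a stated time of 48 h (on this read-out higher numbers stand for weaker inhibition and lower numbers for stronger inhibition), compound 2 gives the higher of the two numbers; compound 1 sits below it by a margin beyond the usual scatter. Compound 3, `Cc1ccc2[nH]cc(Cc3cc4ccccc4[nH]3)c2c1`, keeps the whole of compound 2 and differs in one place: methyl in place of chloro on an aromatic carbon. Among the measured compounds shown here, no pair of measured compounds shows what this change does on this core, so the expected size of the step is open. A step from compound 2 to compound 3 of modest size in either direction, or none beyond the scatter, would be the plain expectation. The estimate for compound 3 in this assay is 8000 nM, with a range from 2500 nM to 25000 nM. This estimate means an expected step of a 1.3-fold lower number from compound 2 to compound 3 (0.10 log units; within the scatter).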

Compound 3, half-maximal inhibitory concentration: 5600 nM
For compound 3 the middle estimate is 1.4-fold (0.15 log units) above the measured one; the range from low to high includes it.
By their numbers in this assay, from the lowest: compounds 1, 3 and 2 (each within the scatter of the next, the first and the last beyond it).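

In this assay, the step at this position is a 1.8-fold lower number from compound 2 to compound 3 (0.25 log units; within the scatter), so on the shared core the read-out does not separate methyl from chloro on this aromatic carbon. Among the compounds shown here, this is the first view of a change at this place: the earlier compounds showed only that moving the chloro could matter, whereas compound 3 shows that the chlorine itself is not needed to keep a number in this range. Nothing available here accounts for this result.

From the compounds shown here alone, whether an amine, a carboxylic acid or a longer chain on the same carbon would stay within the scatter of compound 3 or move beyond it remains open. Going by these compounds, it is also open whether methyl in place of chloro would behave the same way on compound 1, where the chloro sits elsewhere on the core.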